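Methyl Ester to Carboxylic Acid at Orexin Receptor Type 2

The source may report more compounds than this note shows. Statements on the series, on what has been measured and on what is new or still open speak of the compounds shown alone.

Compound 1 `O=Cc1ccc2ccc(C(=O)O)ccc1-2`: 44.1% in an assay on cells for displacement of a labelled ligand from Orexin receptor type 2 (Homo sapiens), read by scintillation counting, with stated times of 10 min and 90 min, tested at 10 uM; on this read-out lower numbers stand for less inhibition and higher numbers for more inhibition at the one concentration tested (going by the name of the read-out)
Compound 2 `COC(=O)c1ccc2c(C=O)cc(-c3ccccc3)c-2cc1`: 1.8% in this assay

Of the compounds shown here, two have been measured in this assay. Compound 2 stands lowest of the two numbers; its nearest neighbour is compound 1, whose number lies higher by a gap that goes beyond the usual scatter of repeated measurements. For the measured compounds named here, no pair of measured compounds differs in a single place, so no measured step can be stated.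

Compound 3 `O=Cc1cc(-c2ccccc2)c2ccc(C(=O)O)ccc1-2` has not yet been measured. It is reached from compound 2 by one change: hydrogen in place of methyl on an oxygen next to a carbonyl group. Read one bond further out, methoxy becomes hydroxy, so methoxycarbonyl becomes carboxy. Compound 1 also carries a carboxy group, and in this assay compound 1 gives 44.1%, while the methoxycarbonyl compound 2 gives 1.8%; these two differ in more than this one place, so this is a hint, not a measured step. An increase in inhibition beyond the scatter is expected in this assay: a number 28.2 percentage points higher from compound 2 to compound 3 (beyond the scatter). Compound 3 is estimated at 30%, with an expected range from 5% to 60%.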

Compound 3, a percentage reported as inhibition, at one concentration (the size of the read-out at that concentration, not a potency): 21.5%
Estimate against measurement, compound 3: 8.5 percentage points above; measured number inside the range.
By their numbers in this assay, from the lowest: compound 2; then compound 3; then compound 1.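

With compound 3, the change from methoxycarbonyl to carboxy can be read on its own in this assay: hydrogen in place of methyl on an oxygen next to a carbonyl group gives a number 19.7 percentage points higher from compound 2 to compound 3 (beyond the scatter) and so restores part of the inhibition on this phenyl-bearing core. A second single change can also be read, with the carboxy group kept in both compounds: phenyl in place of hydrogen on an aromatic carbon gives a number 22.6 percentage points lower from compound 1 to compound 3 (beyond the scatter), so the phenyl compound keeps only part of the inhibition seen without that group. Nothing measured here accounts for either step.

As far as these compounds go, whether an amide or an ethyl ester in place of the carboxy group would read closer to the methyl ester or to the acid remains open, as does the part played by the formyl group that all three compounds share. From the compounds shown here alone, it is also open whether a methyl group or a pyridyl ring in place of the phenyl would lower the inhibition as the phenyl does.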